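The source may hold more compounds than are shown below. What is called first, only, known or untested is meant among the compounds shown, and "the series" means these compounds.

Compound 2, with the structure `NS(=O)(=O)c1cccc(-c2nc(C(c3ccc(F)cc3)c3ccc(F)cc3)sc2CC(=O)O)c1`, and compound 1, with the structure `O=C(O)Cc1sc(NC(=O)c2ccccc2)nc1-c1ccc(Cl)cc1`, were both tested in an in vitro functional assay on HEK285-7 cells for antagonist activity at prostaglandin D2 receptor 2 (Homo sapiens), read by BRET and beta-arrestin recruitment; on this read-out lower numbers stand for stronger inhibition and higher numbers for weaker inhibition. In that assay compound 2 gives 710 nM, while compound 1 gives 870 nM. The two numbers lie within the usual scatter of repeated measurements, so the data do not separate the two compounds in strength; compound 2 simply has the lower of the two numbers on record.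

Compound 3, with the structure `Cc1cc(-c2nc(C(c3ccc(F)cc3)c3ccc(F)cc3)sc2CC(=O)O)cnc1N`, has not yet been measured. It differs from compound 2 in one place: 6-amino-5-methylpyridin-3-yl in place of 3-sulfamoylphenyl on an aromatic carbon. The group that leaves carries one six-membered aromatic ring of carbon only, and the group that enters carries one six-membered aromatic ring with one hetero atom; both carry one hydrogen-bond donor and two hydrogen-bond acceptors.

For the measured compounds named here, no measured pair in this set shows what such a change does, so there is no basis for expecting a step beyond the scatter in either direction. The estimated step in this assay is a 1.4-fold higher number from compound 2 to compound 3 (0.15 log units; within the scatter). For compound 3 the expected result in this assay is 1000 nM, with a range from 300 nM to 3500 nM.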

Compound 3, half-maximal inhibitory concentration: > 100000 nM
Compound 3 was reported as a limit; the forecaster's own chance of this, stated with the estimate: 5%; middle value at least 100-fold (2.00 log units) from the limit.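

In this assay compound 3 gives > 100000 nM, and this value is a limit of the assay, not a number. For the compounds shown here, putting 6-amino-5-methylpyridin-3-yl in place of 3-sulfamoylphenyl gives an at least 140-fold higher number from compound 2 to compound 3 (2.14 log units; beyond the scatter), the first single-place change in this set and one that lies well beyond the scatter. The group on this aromatic carbon, next to the ring nitrogen of the shared core, can therefore decide the read-out even when the counts of hydrogen-bond donors and acceptors stay the same, and how weak compound 3 really is stays hidden behind the limit: the limit of > 100000 nM in this assay, at which 1 of the 3 values shown sits.

The change replaces several features at once, since the sulfamoyl group leaves while a ring hetero atom, an amino group and a methyl group enter, so the data do not say which of these accounts for the step. A 6-aminopyridin-3-yl group without the methyl, or a plain phenyl ring at the same place, would help to separate these parts, and the reason for the loss remains open.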